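The source may report more compounds than this note shows. Statements on the series, on what has been measured and on what is new or still open speak of the compounds shown alone.

Compound 3 `CS(=O)(=O)CCc1ccccc1` gives 0.82 in a physicochemical assay for lipophilicity, read by spectrophotometry, using the shake flask method, measured as octanol-water partition (on this read-out lower numbers stand for lower lipophilicity and higher numbers for higher lipophilicity), the second highest of the three numbers; compound 2 `C[S+]([O-])CCc1ccccc1` gives 0.63, compound 1 `FC(F)SCCc1ccccc1` gives 3.16, and the step of a number 0.19 log units higher from compound 2 to compound 3 (within the scatter) lies within the scatter. Compound 4 `FC(F)CCc1ccccc1` differs from compound 3 by difluoromethyl in place of methylsulfonyl on a saturated chain carbon, two bonds along the chain from an aromatic carbon. The closest measured guide is the step of a number 2.34 log units lower from compound 1 to compound 3 (beyond the scatter), a large drop when a fluorinated sulfanyl group gave way to methylsulfonyl, alongside a number 2.53 log units lower from compound 1 to compound 2 (beyond the scatter). Reversing the direction, a large rise in this assay is expected from compound 3 to compound 4, a number 2.18 log units higher from compound 3 to compound 4 (beyond the scatter), with no measured compound carrying difluoromethyl directly. Compound 4 is therefore estimated at 3, in the range 2.5 to 3.5.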

Compound 4, partition coefficient: 3.02
Estimate against measurement, compound 4: 0.02 log units below; the measured number falls inside the stated range.
By their numbers in this assay, from the lowest: compounds 2 and 3 (each within the scatter of the next); then compounds 4 and 1 (each within the scatter of the next).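

In this assay, the step of a number 2.20 log units higher from compound 3 to compound 4 (beyond the scatter) and the step of a number 2.39 log units higher from compound 2 to compound 4 (beyond the scatter) are both large, so a group without sulfur at this saturated chain carbon, two bonds along the chain from an aromatic carbon, can stand as far from methylsulfonyl as (difluoromethyl)sulfanyl does. Difluoromethyl in place of (difluoromethyl)sulfanyl gives the step of a number 0.14 log units lower from compound 1 to compound 4 (within the scatter) and so stays within the scatter. No evidence is available that accounts for these steps.

The compounds shown leave open where a trifluoromethyl, a plain methyl or an amine at this place would fall. They also leave open whether these steps hold on a longer chain.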